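Alkyne to alkene exchange on the shared core

The source may hold more compounds than are shown below. What is called first, only, known or untested is meant among the compounds shown, and "the series" means these compounds.

Measured so far:
- compound 1, `CCCC(O)(C#Cc1ccc(C(CC)(CC)C2=CN(CC)C(C(=O)NCCN(CC)CC)C2)cc1C)CCC`: 51.1%
- compound 2, `CCCC(O)(C#Cc1ccc(C(CC)(CC)C2=CCC(C(=O)NCCN(CC)CC)N2CC)cc1C)CCC`: 52.1%

The account follows the change from compound 1 to compound 3. In an assay on isolated protein for binding affinity to vitamin D3 receptor (Homo sapiens), read by fluorescence polarization, tested at 1 uM (a lower number here means less inhibition, a higher number more inhibition at the concentration tested (going by the name of the read-out)), compound 1 gives 51.1%, the lowest of the two numbers shown, with compound 2 giving 52.1%, a value within the scatter of compound 1, so the two cannot be placed in order.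

Compound 3, `CCN(CC)CCNC(=O)C1CC(C(CC)(CC)c2ccc(/C=C/C(O)(CC)CC)c(C)c2)=CN1CC`, has not yet been measured in this assay. It differs from compound 1 in one place: a group of 8 heavy atoms (7 carbon, 1 oxygen; no ring) in place of a group of 10 heavy atoms (9 carbon, 1 oxygen; no ring), on an aromatic carbon. The alkyne carrying the tertiary alcohol with two propyl chains is thus replaced by an alkene carrying a tertiary alcohol with two ethyl chains.

Among the measured compounds shown here, no step between measured compounds bears on this change, so the expectation rests on compound 1 alone. Compound 3 is expected to give 47%, between 30% and 64%, a step of a number 4.1 percentage points lower from compound 1 to compound 3 (within the scatter) that is estimated to stay within the scatter.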

Compound 3, a percentage reported as inhibition, at one concentration (the size of the read-out at that concentration, not a potency): 65.5%
The estimate for compound 3 lay 18.5 percentage points below the measured number; measured number outside the range, above it.
By their numbers in this assay, from the lowest: compounds 1 and 2 (each within the scatter of the next); then compound 3.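

In this assay, the group on the aromatic carbon, ortho to a methyl group and para to a large group, turns out to affect the read-out: replacing the alkyne carrying two propyl chains with the alkene carrying two ethyl chains gives a number 14.4 percentage points higher from compound 1 to compound 3 (beyond the scatter). Among the compounds shown here, compound 1 and compound 2 differ elsewhere in the molecule, so this is the first step that can be read at this position, and it shows that the position accepts the alkene with the shorter chains without any loss in the read-out. Nothing measured here accounts for the step.

The step joins two changes, the triple bond becoming a double bond and the propyl chains becoming ethyl chains, and the compounds shown do not separate them; an alkyne carrying two ethyl chains or an alkene carrying two propyl chains would do so. Also open, going by these compounds, is whether the same exchange holds on the core of compound 2, and how butyl chains on the alcohol carbon would read.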